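A Second Chloro Group on a Fused Bicyclic Core

The compounds below may be only part of what the source reports. "The series", "measured", "known", "first", "only" and "open" are said of these compounds alone.

Measured so far, all in a functional assay on MCF7 cells (Homo sapiens) for antiproliferative activity; on this read-out lower numbers stand for stronger inhibition and higher numbers for weaker inhibition:
- compound 1 `Clc1ncnc2ncn(C3COc4ccccc4CO3)c12` gives 1250 nM
- compound 2 `Ic1ncnc2ncn(C3COc4ccccc4CO3)c12` gives 1250 nM
- compound 3 `Clc1ncnc2c1ncn2C1COc2ccccc2CO1` gives 1250 nM

On these numbers compound 1 stands level with compound 2 and compound 3 at the digits shown; no two of the three are separated by more than the usual scatter of this kind of measurement. Among the measured compounds shown here, the only pair that differs in one place is covered by the step of no change at the digits printed from compound 1 to compound 2 (within the scatter), which goes with iodo in place of chloro on an aromatic carbon: swapping one halogen for another left the read-out where it was.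

Compound 4 `Clc1nc(Cl)c2c(ncn2C2COc3ccccc3CO2)n1` differs from compound 1 by chloro in place of hydrogen on an aromatic carbon. For the measured compounds named here, no measured step covers the addition of a chloro group where a hydrogen stood; the one halogen swap is a different kind of change, so it gives only weak guidance. With nothing in the measured data pointing in either direction, compound 1 serves as the anchor and the expected step is no change at the digits printed from compound 1 to compound 4 (within the scatter), none beyond the scatter, with wide uncertainty. Compound 4 is therefore estimated at 1250 nM, with a range from 400 nM to 4000 nM.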

Compound 4, half-maximal inhibitory concentration: 1250 nM
Compound 4: middle estimate and measured number agree at the digits printed; the measured number falls inside the stated range.
By their numbers in this assay, from the lowest: compounds 1, 2, 3 and 4 (each within the scatter of the next).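

In this assay, putting a chloro group where a hydrogen stood gives this result: no change at the digits printed from compound 1 to compound 4 (within the scatter). The earlier compounds shown here showed only one halogen exchanged for another, whereas this step adds a second halogen to the core, on an aromatic carbon between two ring nitrogen atoms, and the read-out stays level with that of compound 1. Nothing available explains why this added chloro group leaves the number where it was.

A chloro group is a single atom, so these compounds say nothing about whether a larger group, such as an amine, a methoxy group or a longer chain, would be tolerated on this same carbon. From the compounds shown here alone, it also remains open whether any group here can move the read-out beyond the scatter in either direction.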